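Swapping Dichlorophenyl for Methoxyphenyl on a Shared Core

The compounds below may be only part of what the source reports. "The series", "measured", "known", "first", "only" and "open" are said of these compounds alone.

Compound 1 `CCOC(=O)[C@H](CCC(=O)O)NC(=O)c1ccc(CNc2nc3cc(N)cc(N)c3nc2-c2ccccc2)cc1` in a functional assay on SF-295 cells (Homo sapiens) for inhibition, read by sulforhodamine B assay, with a stated time of 48 h (a lower number here means that less compound is tolerated, a higher number that more compound is tolerated), is reported only as a limit of the assay, < 100000 nM.
Compound 2 `Nc1cc(N)c2nc(-c3ccccc3)c(NCc3ccc(Cl)c(Cl)c3)nc2c1` in this assay gives 89100 nM.

Within the data shown here, compound 2 therefore holds the only actual number here. The entry for compound 1 is a limit, not a number (the limit of < 100000 nM in this assay, at which 1 of the 2 values shown sits). Compound 3 `COc1ccc(CNc2nc3cc(N)cc(N)c3nc2-c2ccccc2)cc1` differs from compound 2 by 4-methoxyphenyl in place of 3,4-dichlorophenyl on a saturated chain carbon bound to a nitrogen on an aromatic ring. No measured pair differing in one place exists among these compounds, so this change has no precedent in the data. The step from compound 2 to compound 3 is expected to be a 1.1-fold higher number from compound 2 to compound 3 (0.03 log units; within the scatter), not beyond the usual scatter. Compound 3 is thus estimated at 95000 nM, within a range from 40000 nM to 200000 nM.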

Compound 3, concentration lethal to 50% of the cells: 58900 nM
For compound 3 the middle estimate is 1.6-fold (0.21 log units) above the measured one; the measured number falls inside the stated range.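

Among these compounds, this is the first measured one-place step in the set. In this assay, the change to 4-methoxyphenyl gives a 1.5-fold lower number from compound 2 to compound 3 (0.18 log units; within the scatter) and so, on a saturated chain carbon bound to a nitrogen on an aromatic ring, the two groups cannot be told apart, even though one carries chlorine and the other oxygen. Nothing given here bears on a cause for this result.

On these data alone, whether a trifluoromethylphenyl or a phenyl bearing a nitrile at this place would move the number beyond the usual scatter stays open. So does whether the same swap would look alike on other cells.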